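This account rests on a few compounds, and the source may have more. Where it says the series, first, only, none or still open, it means among the compounds named here.

For the measured compounds named here, compound 1 `CC(C)(C)c1ccc(C(=O)N/N=C/c2cc(I)cc(I)c2O)cc1` and compound 2 `O=C(N/N=C/c1cc(I)cc(I)c1O)c1ccc(O)cc1` share a core; in a functional assay on HepG2 cells (Homo sapiens) for cytotoxicity, with a stated time of 24 h (on this read-out lower numbers stand for stronger inhibition and higher numbers for weaker inhibition), compound 1 gives 41600 nM and compound 2 gives 19200 nM, the lowest of the two numbers, the one measured step being a 2.2-fold lower number from compound 1 to compound 2 (0.34 log units; beyond the scatter). Compound 3 `O=C(N/N=C/c1cc(I)cc(I)c1O)c1ccc(Br)cc1` is not yet measured; against compound 2 the change is bromo in place of hydroxy on an aromatic carbon. Going by the values given here, only that single step bears on it, and it ran the other way, from a bulky group to hydroxy. Taking hydroxy out again is therefore expected to raise the number modestly, a 1.6-fold higher number from compound 2 to compound 3 (0.19 log units; within the scatter), with compound 3 estimated at 30000 nM (range 12000 nM to 75000 nM).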

Compound 3, half-maximal inhibitory concentration: 22300 nM
Beside the measured number, compound 3's estimate is 1.3-fold (0.13 log units) above it; the range from low to high includes it.
By their numbers in this assay, from the lowest: compounds 2, 3 and 1 (each within the scatter of the next, the first and the last beyond it).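

In this assay, bromo in place of hydroxy gives a 1.2-fold higher number from compound 2 to compound 3 (0.07 log units; within the scatter) and so shows that, at this position, losing the hydrogen-bond donor and acceptor counted on hydroxy does not carry the number beyond the scatter. Bromo in place of tert-butyl gives a 1.9-fold lower number from compound 1 to compound 3 (0.27 log units; within the scatter) and so leaves compound 3 within the scatter of both compound 1 and compound 2, although those two lie beyond it from each other. Nothing at hand explains these steps.

Open, from the compounds shown here alone, is whether an amine or a carboxylic acid at this position would give a step beyond the scatter. Also open, going by these compounds, is whether a longer chain there would stay within it.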